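The source may hold more compounds than are shown below. What is called first, only, known or untested is meant among the compounds shown, and "the series" means these compounds.

Working notes on the series in a functional assay on OVCAR-8 cells (Homo sapiens) for inhibition; a lower number here means a stronger inhibitor of growth, a higher number a weaker inhibitor of growth. Going by the values given here, compound 2 `NC(=O)c1cc(I)ccc1NC(=O)COc1ccccc1` gives 904 nM, the lower of the two numbers so far, while compound 1 `NC(=O)c1cc(Cl)ccc1NC(=O)COc1ccccc1` gives 7060 nM. Among the compounds with values here, the only measured step, a 7.8-fold lower number from compound 1 to compound 2 (0.89 log units; beyond the scatter), is iodo in place of chloro on an aromatic carbon. It lies beyond the scatter and is modest in size.

The next change leads to compound 3 `COc1ccc(NC(=O)COc2ccccc2)c(C(N)=O)c1`, with methoxy in place of iodo on an aromatic carbon. The new group sits on the same aromatic carbon that carries the halogen in compound 1 and compound 2. Within the data shown here, no compound with methoxy has been measured yet, so the single halogen step is the only guide, and an indirect one. Compound 2 holds the lowest number in this small set, and the exchange of its iodo for chloro in compound 1 cost the whole of a 7.8-fold lower number from compound 1 to compound 2 (0.89 log units; beyond the scatter). A move of similar size towards a higher number in this assay is therefore expected on losing iodo, with wide uncertainty. The expected step is a 6.6-fold higher number from compound 2 to compound 3 (0.82 log units; beyond the scatter). For compound 3 the estimate is 6000 nM, with an expected range of 2000 nM to 18000 nM.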

Compound 3, concentration for 50% growth inhibition: 3130 nM
Beside the measured number, compound 3's estimate is 1.9-fold (0.28 log units) above it; the measured number falls inside the stated range.
By their numbers in this assay, from the lowest: compound 2; then compound 3; then compound 1.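

In this assay, the order at this position is no longer a matter of halogens alone: methoxy in place of iodo gives a 3.5-fold higher number from compound 2 to compound 3 (0.54 log units; beyond the scatter), while methoxy in place of chloro gives a 2.3-fold lower number from compound 1 to compound 3 (0.35 log units; beyond the scatter). A group that is not a halogen, on the aromatic carbon para to a large group and meta to a carbamoyl group, therefore lands between the two halogens, with all three compounds separated by steps beyond the scatter and compound 2 still holding the lowest number. Going by these compounds alone, this shows that iodo is not the only group at this position that improves on chloro, although methoxy recovers only part of the gain seen with iodo, and nothing available bears on why the three groups fall in this order.

As far as these compounds go, three groups at a single position do not establish a trend, so it remains open where bromo, an amine, a carboxylic acid or a longer ether chain such as ethoxy would fall relative to iodo and methoxy. From the compounds shown here alone, it is also open whether the same order would hold with changes elsewhere in the shared core, since all three compounds differ only at this one carbon.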